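Inverting One Ring Stereocentre: Compound 3 to Compound 4

The source may hold more compounds than are shown below. What is called first, only, known or untested is meant among the compounds shown, and "the series" means these compounds.

Of the compounds shown here, three have so far been measured in a functional assay on A549 cells (Homo sapiens) for cytotoxicity, read by MTT assay, with a stated time of 24 h; on this read-out lower numbers stand for stronger inhibition and higher numbers for weaker inhibition. Compound 1 `CC(=O)OC[C@H]1O[C@H](NS(N)(=O)=O)C=C[C@@H]1OC(C)=O` gives 704000000 nM. Compound 2 `CC(=O)OC[C@H]1O[C@H](NS(=O)(=O)c2ccc(C)cc2)C(OC(C)=O)=C[C@@H]1OC(C)=O` gives 34900000 nM. Compound 3 `CC(=O)OC[C@H]1O[C@H](NS(=O)(=O)c2ccc(C)cc2)C=C[C@@H]1OC(C)=O` gives 829000000 nM, the highest of the three numbers; its nearest neighbour is compound 1, and that gap, a 1.2-fold higher number from compound 1 to compound 3 (0.07 log units; within the scatter), is within the scatter, so the two cannot be ranked against each other. The furthest neighbour is compound 2, and that gap, a 24-fold higher number from compound 2 to compound 3 (1.38 log units; beyond the scatter), is large.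

The next compound, compound 4 `CC(=O)OC[C@H]1O[C@H](NS(=O)(=O)c2ccc(C)cc2)C=C[C@H]1OC(C)=O`, differs from compound 3 in a single respect: the two compounds have the same atoms and bonds and differ only in configuration as drawn: 1 of 3 stereo elements differ; a stereocentre at a saturated ring carbon is drawn S in compound 3 and R in compound 4. Neither measured step bears directly on such a change. The step from compound 1 to compound 3 exchanged the group on the sulfonyl sulfur and stayed within the scatter, while the step from compound 2 to compound 3 removed an acetoxy group and moved the number a great deal. Both altered which atoms are present; compound 4 alters only how they are arranged in space. With no guidance from a comparable step, the expectation for compound 4 is no change beyond the scatter, a 1.0-fold lower number from compound 3 to compound 4 (0.02 log units; within the scatter), with wide uncertainty. Compound 4 is therefore estimated at 800000000 nM, with a range from 200000000 nM to 3000000000 nM.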

Compound 4, half-maximal inhibitory concentration: > 1000000000 nM
Compound 4 ended at the assay's limit; the forecaster's own chance of this, stated with the estimate: 10%; at least 1.2-fold (0.09 log units) between middle value and limit.
By their numbers in this assay, from the lowest: compound 2; then compounds 1 and 3 (each within the scatter of the next). At a limit, above all of these: compound 4.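

In this assay compound 4 gives > 1000000000 nM, which is a limit of the assay and not a number: the limit of > 1000000000 nM in this assay, at which 1 of the 4 values shown sits. The comparison therefore yields only a floor, an at least 1.2-fold higher number from compound 3 to compound 4 (0.08 log units; that floor lies within the scatter), so turning this one stereocentre from S to R gave no sign of stronger inhibition, and how far the true value of compound 4 lies past the limit cannot be told. Unlike the earlier steps, which exchanged or removed atoms, this one isolates spatial arrangement at a saturated ring carbon, and the only structural difference to point to is this: the fact that compounds 3 and 4 differ only in the configuration as drawn.

The compounds shown leave open whether the same inversion would matter with an acetoxy group on the double-bonded ring carbon, the feature that sets compound 2 apart from compound 3, and compound 2 gives 34900000 nM. They also leave open what a hydroxyl group or an amine would do in place of the acetoxy group on the saturated ring carbon whose configuration changed, in either the S or the R form.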